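Swapping a chain's hydroxy end for a methylpiperazine group

A few compounds are considered here, and "the series" means these few. Any claim that something is new, unique, unknown or untested is made for them only; others in the source may bear on it.

In a functional assay on K562 cells (Homo sapiens) for antiproliferative activity, read by MTT assay, with a stated time of 48 h (on this read-out higher numbers stand for weaker inhibition and lower numbers for stronger inhibition), compound 1 `CCCn1c(N)c(-c2nc3ccccc3[nH]2)c2nc(C#N)c(C#N)nc21` gives > 50000 nM which is a limit of the assay and not a number. Compound 2 `N#Cc1nc2c(-c3nc4ccccc4[nH]3)c(N)n(CCO)c2nc1C#N` gives > 50000 nM which is likewise a limit and not a number. Compound 2 therefore stands at the limit of > 50000 nM in this assay, at which 2 of the 2 values shown sit, with no number to place it.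

Among the measured compounds shown here, the one measured step is a step that the two limits leave unreadable from compound 1 to compound 2 and it offers no size to carry forward. Compound 3 `CN1CCN(CCCn2c(N)c(-c3nc4ccccc4[nH]3)c3nc(C#N)c(C#N)nc32)CC1` is still unmeasured. Its difference from compound 2 is (4-methylpiperazin-1-yl)methyl in place of hydroxy on a saturated chain carbon, two bonds along the chain from an aromatic nitrogen and the side chain thus goes from 2-hydroxyethyl to 3-(4-methylpiperazin-1-yl)propyl. The earlier step swapped only hydroxy and methyl, so it says little about this new group.

Since compound 2 gives > 50000 nM as a limit, a readable result could only point toward stronger inhibition. The expected move is an at least 2.0-fold lower number from compound 2 to compound 3 (0.30 log units; that floor lies within the scatter) and it is a cautious guess. For compound 3 the estimated value is 25000 nM with an expected range from 5000 nM to 50000 nM in this assay and another limit remains quite possible.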

Compound 3, half-maximal inhibitory concentration: 1260 nM
Compound 3: the middle estimate sits 20-fold (1.30 log units) above what was measured; the measured number lies below the stated range.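

Among the compounds shown here, the 3-(4-methylpiperazin-1-yl)propyl side chain gives the first readable number in this assay, where compound 3 reaches 1260 nM. Replacing the hydroxy end of the chain gives an at least 39-fold lower number from compound 2 to compound 3 (1.59 log units; beyond the scatter), and adding the methylpiperazine to the end of the propyl chain gives an at least 39-fold lower number from compound 1 to compound 3 (1.59 log units; beyond the scatter), so a change at this place on the chain can move the read-out clearly, something the hydroxy and methyl swap could not show, as that step cannot be read. Both sizes are floors and not exact figures, because each step starts from a limit of the assay: the limit of > 50000 nM in this assay, at which 2 of the 3 values shown sit.

With a single side chain giving a number, the compounds shown do not separate the part played by the whole methylpiperazine from that of a simpler amine, so a chain ending in dimethylamino or in morpholine would be the informative comparison. Going by these compounds, how the length of the chain matters also stays open, since a butyl chain ending in the same methylpiperazine would test a spacing that none of these three compounds carries.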